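The compounds below may be only part of what the source reports. "The series", "measured", "known", "first", "only" and "open" are said of these compounds alone.

Measured compounds:
compound 1 `CN1CCN(c2ccc(Nc3ncc4nc(Nc5ccc(F)cc5)n([C@H]5CCCNC5)c4n3)cc2)CC1` 38 nM
compound 2 `CN1CCN(c2ccc(Nc3ncc4nc(Nc5ccc(F)cc5)n([C@@H]5CCN(S(=O)(=O)C6CC6)C5)c4n3)cc2)CC1` 2.5 nM
compound 3 `CN1CCN(c2ccc(Nc3ncc4nc(Nc5ccc(F)cc5)n([C@H]5CCN(C(=O)CO)C5)c4n3)cc2)CC1` 380 nM

In a functional assay on HCC827 cells (Homo sapiens) for antiproliferative activity, read by MTT assay, with a stated time of 72 h (a higher number here means a weaker inhibitor, a lower number a stronger inhibitor), compound 3 gives the highest number of the three, with a 10-fold higher number from compound 1 to compound 3 (1.00 log units; beyond the scatter) and a 150-fold higher number from compound 2 to compound 3 (2.18 log units; beyond the scatter). Compound 4 `CCOC(=O)CN1CC[C@H](n2c(Nc3ccc(F)cc3)nc3cnc(Nc4ccc(N5CCN(C)CC5)cc4)nc32)C1` differs from compound 3 by (ethoxycarbonyl)methyl in place of (hydroxymethyl)carbonyl on an amine nitrogen in a ring. For the measured compounds named here, the steps that bear on this position are a 15-fold lower number from compound 1 to compound 2 (1.18 log units; beyond the scatter) and a 150-fold higher number from compound 2 to compound 3 (2.18 log units; beyond the scatter); both show that the group on this ring nitrogen moves the number strongly in either direction, and compound 1, which carries an unsubstituted ring nitrogen at this place, gives 38 nM. Because the (hydroxymethyl)carbonyl group of compound 3 gave a 10-fold higher number from compound 1 to compound 3 (1.00 log units; beyond the scatter), its removal is expected to lower the number again, so compound 4 is estimated at 60 nM (range 15 nM to 250 nM), a step of a 6.3-fold lower number from compound 3 to compound 4 (0.80 log units; beyond the scatter).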

Compound 4, half-maximal inhibitory concentration: 1810 nM
Estimate against measurement, compound 4: 30-fold (1.48 log units) below, outside the stated range (above it).
By their numbers in this assay, from the lowest: compound 2; then compound 1; then compound 3; then compound 4.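

Putting (ethoxycarbonyl)methyl in place of (hydroxymethyl)carbonyl on this ring nitrogen raises the number further, with a 4.8-fold higher number from compound 3 to compound 4 (0.68 log units; beyond the scatter) rather than a return towards compound 1. Compound 4 is thus the weakest of the four, with a 720-fold higher number from compound 2 to compound 4 (2.86 log units; beyond the scatter) and a 48-fold higher number from compound 1 to compound 4 (1.68 log units; beyond the scatter) as well; both carbonyl-bearing groups give higher numbers than compound 1, and only the cyclopropylsulfonyl group of compound 2 goes against this. No measurement given here accounts for these differences.

As far as these compounds go, whether a carboxylic acid or a plain ethyl chain on this ring nitrogen would lie nearer compound 2 or compound 4 stays open. So does the effect of a sulfonyl group carrying a methyl in place of the cyclopropyl.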